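A Methoxy Group Added to the Weakest of Three Compounds

A few compounds are considered here, and "the series" means these few. Any claim that something is new, unique, unknown or untested is made for them only; others in the source may bear on it.

In a functional assay on KYSE-450 cells (Homo sapiens) for inhibition, read by MTT assay, with a stated time of 48 h (a higher number here means a weaker inhibitor, a lower number a stronger inhibitor), compound 3 `C/C=C/C(=O)N(Cc1cccc(O)c1)c1cc(OC)c(OC)c(OC)c1` gives 14700 nM, the highest number of the three measured and the weakest inhibitor among them. Compound 1 `COc1ccc(CN(C(=O)CO)c2cc(OC)c(OC)c(OC)c2)cc1O` gives 370 nM and compound 2 `COc1ccc(CN(C(=O)CCl)c2cc(OC)c(OC)c(OC)c2)cc1O` gives 210 nM, both far from compound 3 and beyond the scatter. Compound 4 `C/C=C/C(=O)N(Cc1ccc(OC)c(O)c1)c1cc(OC)c(OC)c(OC)c1` keeps everything in compound 3 except for one change: methoxy in place of hydrogen on an aromatic carbon, ortho to a hydroxy group and para to a large group, so that 3-hydroxyphenyl becomes 3-hydroxy-4-methoxyphenyl (methoxy in place of hydrogen on an aromatic carbon).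

Within the data shown here, no measured step makes this change directly. Compound 1 and compound 2 already carry 3-hydroxy-4-methoxyphenyl, but they also differ from compound 3 in the group on the carbonyl, so their gap to compound 3 cannot be assigned to the methoxy alone. Among the measured compounds shown here, the one measured step, a 1.8-fold lower number from compound 1 to compound 2 (0.25 log units; within the scatter), replaces hydroxy with chloro in that region and stays within the scatter, which gives a modest hint that this region may matter little. A large step towards a lower number is therefore expected, with real uncertainty. The estimated step is a 59-fold lower number from compound 3 to compound 4 (1.77 log units; beyond the scatter). Compound 4 is expected at 250 nM, within an estimated range of 50 nM to 1800 nM.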

Compound 4, half-maximal inhibitory concentration: 67 nM
Estimate against measurement, compound 4: 3.7-fold (0.57 log units) above; low and high end bracket the measured number.
By their numbers in this assay, from the lowest: compound 4; then compounds 2 and 1 (each within the scatter of the next); then compound 3.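

In this assay the step of a 220-fold lower number from compound 3 to compound 4 (2.34 log units; beyond the scatter) measures this change directly, showing that methoxy in place of hydrogen on this aromatic carbon, ortho to a hydroxy group and para to a large group, is by itself a large change with prop-1-en-1-yl on the carbonyl carbon. With 3-hydroxy-4-methoxyphenyl held fixed, the group on the carbonyl carbon also proves not to be indifferent: prop-1-en-1-yl in place of chloromethyl gives a 3.1-fold lower number from compound 2 to compound 4 (0.50 log units; beyond the scatter) and prop-1-en-1-yl in place of hydroxymethyl gives a 5.5-fold lower number from compound 1 to compound 4 (0.74 log units; beyond the scatter) as modest steps beyond the scatter, although the exchange between those two groups, a 1.8-fold lower number from compound 1 to compound 2 (0.25 log units; within the scatter), stays within it. Nothing measured here accounts for the size of the methoxy step.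

The compounds shown leave open whether the methoxy step would be as large with chloromethyl or hydroxymethyl on the carbonyl carbon, and whether it depends on the hydroxy group. They also leave open how another group at this place, such as ethoxy, fluoro or an amine, would compare with methoxy.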